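Para substituent series: removing the methoxy group

The source may report more compounds than this note shows. Statements on the series, on what has been measured and on what is new or still open speak of the compounds shown alone.

compound 1 `CC(Nc1ccccc1Oc1ccc(Cl)cc1)=C1C(=O)CC(c2ccccc2)CC1=O` in a functional assay on HeLa cells (Homo sapiens) for antiproliferative activity, read by cell counting, with a stated time of 3 days (a lower number here means a stronger inhibitor, a higher number a weaker inhibitor), gives 500 nM as its value
compound 2 `CC(=O)c1ccc(Oc2ccccc2NC(C)=C2C(=O)CC(c3ccccc3)CC2=O)cc1` gives 130 nM as its value
compound 3 `COc1ccc(Oc2ccccc2NC(C)=C2C(=O)CC(c3ccccc3)CC2=O)cc1` gives 160 nM as its value

Compound 3 cannot be separated from the acetyl analogue (a 1.2-fold higher number from compound 2 to compound 3 (0.09 log units; within the scatter)), while the chloro analogue differs more clearly (a 3.1-fold lower number from compound 1 to compound 3 (0.49 log units; beyond the scatter)). The next change gives compound 4 `CC(Nc1ccccc1Oc1ccccc1)=C1C(=O)CC(c2ccccc2)CC1=O`, with hydrogen in place of methoxy on an aromatic carbon, para to a large group (hydrogen in place of methoxy on an aromatic carbon). Among the measured compounds shown here, no measured compound carries hydrogen there. For the measured compounds named here, the only guides are the swaps among substituents at this place, which were modest at most (a 3.8-fold lower number from compound 1 to compound 2 (0.59 log units; beyond the scatter)). A modest rise in this assay is therefore expected, though its direction is uncertain. The expected step is a 1.8-fold higher number from compound 3 to compound 4 (0.24 log units; within the scatter) (an estimate). Compound 4 is estimated at 280 nM (expected range 100 nM to 750 nM).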

Compound 4, half-maximal inhibitory concentration: 79 nM
The estimate for compound 4 lay 3.5-fold (0.55 log units) above the measured number, outside the stated range (below it).
By their numbers in this assay, from the lowest: compounds 4, 2 and 3 (each within the scatter of the next, the first and the last beyond it); then compound 1.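

Hydrogen at this place on the phenoxy group costs nothing in this assay and is the first sign that no substituent is needed here: methoxy gives way with a 2.0-fold lower number from compound 3 to compound 4 (0.31 log units; beyond the scatter) and chloro with a 6.3-fold lower number from compound 1 to compound 4 (0.80 log units; beyond the scatter) as the larger step. Acetyl goes against this trend, since a 1.6-fold lower number from compound 2 to compound 4 (0.22 log units; within the scatter) leaves hydrogen and acetyl unseparated. No measurement available here explains these steps.

Open, on these data alone, is whether an amine or a carboxylic acid at this place would keep the number of compound 4 or raise it, and whether the steps seen here carry over to other cell lines.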